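From Amino to (Dimethylamino)methyl: Expected Potency of Compound 3

This account rests on a few compounds, and the source may have more. Where it says the series, first, only, none or still open, it means among the compounds named here.

Measured so far:
Compound 1 `Nc1ccc(-c2cc(=O)c3c(N)c(F)c(N)c(F)c3o2)cc1F` gives 7.7 nM in a functional assay on MCF7 cells (Homo sapiens) for cytotoxicity, read by neutral red uptake, with a stated time of 3 days; a higher number here means a weaker inhibitor, a lower number a stronger inhibitor.
Compound 2 `CCCCCCCCCC(=O)OCc1c(F)c(N)c2c(=O)cc(-c3ccc(N)c(F)c3)oc2c1F` gives 100 nM in this assay.

Of the two numbers in hand, compound 1 holds the lowest. Its nearest neighbour is compound 2, whose number lies higher by a margin beyond the usual scatter of repeated measurements, so compound 1 is the stronger inhibitor of the pair.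

Compound 3 `CN(C)Cc1c(F)c(N)c2c(=O)cc(-c3ccc(N)c(F)c3)oc2c1F` has not yet been measured in this assay. It differs from compound 1 in one place: (dimethylamino)methyl in place of amino on an aromatic carbon. The change sits on an aromatic carbon of a six-membered aromatic ring of carbon only, part of a fused system of two rings, ortho to two fluoro groups and meta to an amino group.

Within the data shown here, no step between measured compounds isolates this change, so the expectation rests on the values alone. Because compound 2 gives 100 nM while compound 1 gives 7.7 nM, the only other alteration of the shared core seen here goes with a weaker inhibitor. A moderate rise in the number is therefore expected, a 4.5-fold higher number from compound 1 to compound 3 (0.66 log units; beyond the scatter), beyond the scatter but short of the gap to compound 2. Compound 3 is estimated at 35 nM, with a range from 10 nM to 150 nM.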

Compound 3, half-maximal inhibitory concentration: 72 nM
Estimate against measurement, compound 3: 2.1-fold (0.31 log units) below; low and high end bracket the measured number.
By their numbers in this assay, from the lowest: compound 1; then compounds 3 and 2 (each within the scatter of the next).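

Among these compounds, the step of a 9.4-fold higher number from compound 1 to compound 3 (0.97 log units; beyond the scatter) gives the first direct reading of this position in this assay, on the aromatic carbon ortho to two fluoro groups, and it shows that replacing amino with (dimethylamino)methyl there goes with a weaker inhibitor. The step is modest, however, and compound 3 still gives 72 nM, so this larger group, with 4 heavy atoms in place of 1 and no hydrogen-bond donor, does not abolish activity in this assay. Among the compounds shown here, no accompanying measurement bears on the result, and the single step cannot show what lies behind the rise.

The compounds shown leave open which part of the change goes with the rise: the added carbon that carries the nitrogen, the two methyl groups on it, or the loss of the amino group itself. An aminomethyl group or a dimethylamino group set directly on the same aromatic carbon would separate these parts, and a hydroxymethyl group there would show whether a nitrogen is needed at all.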